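From compound 3 to compound 4: notes on the side group

This account rests on a few compounds, and the source may have more. Where it says the series, first, only, none or still open, it means among the compounds named here.

Values so far in an ADME assay on microsomes from liver (Homo sapiens) for metabolic stability (a higher number here means that the compound lasts longer, a lower number that the compound disappears faster), are:
- compound 1 `CC(C)C(c1nnc[nH]1)c1ccc(-c2ccc3cccc(F)c3c2)[nH]c1=O` gives 0.905 h
- compound 2 `CC(C)C(Cc1noc(=O)[nH]1)c1ccc(-c2ccc3cccc(F)c3c2)[nH]c1=O` gives > 3 h as a limit of the assay, not a number
- compound 3 `CC(C)C(/C=C1/CCNC1=O)c1ccc(-c2ccc3cccc(F)c3c2)[nH]c1=O` gives 0.987 h

Compound 3 lies within the scatter of compound 1, and only compound 2 stands apart from this pair.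

Compound 4 `CC(C)NC(=O)CC(c1ccc(-c2ccc3cccc(F)c3c2)[nH]c1=O)C(C)C` is the next entry, with the change a group of 7 heavy atoms (5 carbon, 1 nitrogen, 1 oxygen; no ring) in place of a group of 7 heavy atoms (5 carbon, 1 nitrogen, 1 oxygen; one five-membered non-aromatic ring with 1 hetero atom), on a saturated chain carbon bound to an aromatic carbon and a saturated chain carbon here: (isopropylcarbamoyl)methyl enters and the five-membered non-aromatic ring leaves. All three measured steps sit on this same saturated chain carbon. There a 1.1-fold higher number from compound 1 to compound 3 (0.04 log units; within the scatter) stays within the scatter, whereas an at least 3.3-fold higher number from compound 1 to compound 2 (0.52 log units; beyond the scatter) and an at least 3.0-fold lower number from compound 2 to compound 3 (0.48 log units; beyond the scatter) go beyond it. Both of these larger steps rest on the limit of compound 2.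

Like compound 3, compound 4 has no aromatic ring in this group. The step within the scatter is therefore taken as the closer guide, and no step beyond the scatter is expected in this assay in either direction. This estimate means a 1.0-fold higher number from compound 3 to compound 4 (0.01 log units; within the scatter) as the expected step. For compound 4 the estimated value is 1 h with an expected range from 0.45 h to 2.4 h in this series.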

Compound 4, half-life: 0.32 h
Estimate against measurement, compound 4: 3.1-fold (0.49 log units) above; measured number outside the range, below it.
By their numbers in this assay, from the lowest: compound 4; then compounds 1 and 3 (each within the scatter of the next). At a limit, above all of these: compound 2.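

At the saturated chain carbon bound to an aromatic carbon and a saturated chain carbon, this assay now shows steps beyond the scatter between two numbers, not only against a limit: a 3.1-fold lower number from compound 3 to compound 4 (0.49 log units; beyond the scatter) and a 2.8-fold lower number from compound 1 to compound 4 (0.45 log units; beyond the scatter). The groups exchanged from compound 3 to compound 4 have the same counts of heavy atoms, hydrogen-bond donors and hydrogen-bond acceptors, and neither carries a net charge, so these counts alone do not set the number here; the printed differences are the loss of the five-membered non-aromatic ring and one fewer double bond outside aromatic rings. The widest step, an at least 9.3-fold lower number from compound 2 to compound 4 (0.97 log units; beyond the scatter), places compound 4 lowest of the four but rests on a limit of compound 2, not on a number: the limit of > 3 h in this assay, at which 1 of the 4 values shown sits.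

Open, on these data alone, is whether the lower number goes with the open chain as such or with its isopropyl end, a question that a methyl or a tert-butyl on the amide nitrogen, or a carboxylic acid in place of the whole amide, would address. As far as these compounds go, how far compound 2 truly lies from the other three also stays unknown.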